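Adding two methoxy groups to a benzyl amine cytotoxicity probe

This account rests on a few compounds, and the source may have more. Where it says the series, first, only, none or still open, it means among the compounds named here.

Compound 1 `COc1ccc(CNc2nc(=O)c3cc(C(F)(F)F)cc([N+](=O)[O-])c3o2)cc1OC` and compound 2 `CN(Cc1ccccc1)c1nc(=O)c2cc(C(F)(F)F)cc([N+](=O)[O-])c2o1` were both tested in an ADME assay on Vero cells (Chlorocebus sabaeus) for cytotoxicity, read by MTT assay, with a stated time of 48 h; a higher number here means a weaker inhibitor, a lower number a stronger inhibitor. Compound 1 gives 29.2 ug/mL, while compound 2 gives 3.84 ug/mL, the lower of the two numbers, and the gap between them lies beyond the scatter. Compound 3 `COc1ccc(CN(C)c2nc(=O)c3cc(C(F)(F)F)cc([N+](=O)[O-])c3o2)cc1OC` has not yet been measured in this assay. It differs from compound 2 by 3,4-dimethoxyphenyl in place of phenyl on a saturated chain carbon bound to a nitrogen on an aromatic ring. Going by the values given here, no measured pair isolates this change, so the step is expected to be modest and upward, at a 2.6-fold higher number from compound 2 to compound 3 (0.42 log units; beyond the scatter). Compound 3 is therefore estimated at 10 ug/mL, within a range from 3 ug/mL to 35 ug/mL.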

Compound 3, half-maximal inhibitory concentration: 9.46 ug/mL
Compound 3: middle estimate off by 1.1-fold (0.02 log units), on the high side, within the range that was stated.
By their numbers in this assay, from the lowest: compound 2; then compound 3; then compound 1.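

In this assay the swap of phenyl for 3,4-dimethoxyphenyl gives a 2.5-fold higher number from compound 2 to compound 3 (0.39 log units; beyond the scatter) with methyl on the nitrogen, so this position responds to the change. Methyl in place of hydrogen on that nitrogen gives a 3.1-fold lower number from compound 1 to compound 3 (0.49 log units; beyond the scatter) and thus also moves the number on its own, with both steps beyond the scatter. No measurement at hand offers a cause for either step. From the compounds shown here alone, it remains open whether a single methoxy group on the phenyl ring would give a step of similar size. Going by these compounds, an ethyl group on the nitrogen also remains untested here.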